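A few compounds are considered here, and "the series" means these few. Any claim that something is new, unique, unknown or untested is made for them only; others in the source may bear on it.

In a functional assay on OVCAR-3 cells (Homo sapiens) for cytotoxicity, read by MTT assay, with a stated time of 6 days (a higher number here means a weaker inhibitor, a lower number a stronger inhibitor), compound 1 (`CC(=O)N[C@@H](CSC(=O)Nc1ccccc1F)C(=O)O`) gives > 200000 nM as its reading, which is a limit and not a number. Compound 2 (`CC(=O)N[C@@H](CSC(=O)Nc1ccccc1Cl)C(=O)O`) gives > 200000 nM as its reading, again a limit. Going by the values given here, compound 3 (`CC(=O)N[C@@H](CSC(=O)Nc1ccccc1)C(=O)O`) gives 153000 nM as the only true number in the set. The rest of the picture is the limit of > 200000 nM in this assay, at which 2 of the 3 values shown sit, and nothing firmer.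

Compound 4 (`CSc1ccccc1NC(=O)SC[C@H](NC(C)=O)C(=O)O`) departs from compound 3 by methylsulfanyl in place of hydrogen on an aromatic carbon in one place, with methylsulfanyl in place of hydrogen on an aromatic carbon, ortho to a large group. Among the compounds with values here, two measured steps bear on this, since each also exchanges a group on an aromatic carbon for hydrogen. They are an at least 1.3-fold lower number from compound 1 to compound 3 (0.11 log units; that floor lies within the scatter) and an at least 1.3-fold lower number from compound 2 to compound 3 (0.11 log units; that floor lies within the scatter) and, read backwards, they are the closest guide to putting a group back. Both give only a floor, so neither shows a firm size. The third step, a step that the two limits leave unreadable from compound 1 to compound 2, offers nothing to build on.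

No step beyond the scatter is therefore expected in this assay, and compound 4 may well return only a limit. The estimated change is a 1.1-fold higher number from compound 3 to compound 4 (0.05 log units; within the scatter) in all. Compound 4 is estimated at 170000 nM with an expected range from 80000 nM to 300000 nM in this assay.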

Compound 4, half-maximal inhibitory concentration: > 200000 nM
Compound 4 ended at the assay's limit; the forecaster's own chance of this, stated with the estimate: 50%; middle value at least 1.1-fold (0.07 log units) away from the limit.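

In this assay the position ortho to a large group now carries a third substituent, and compound 4 gives > 200000 nM, which is a limit of the assay and not a number. Going by these compounds alone, the one readable step is an at least 1.3-fold higher number from compound 3 to compound 4 (0.11 log units; that floor lies within the scatter), so methylsulfanyl, a group with 2 heavy atoms including a sulfur, shows no gain over hydrogen here, and the size of any loss stays unknown. The steps from compound 1 and from compound 2 to compound 4 cannot be read, and fluoro, chloro and methylsulfanyl cannot be ranked against one another, since all three compounds rest on the same ceiling: the limit of > 200000 nM in this assay, at which 3 of the 4 values shown sit.

Going by these compounds, the true values of compound 1, compound 2 and compound 4 remain open, as does whether any group at this position would bring the number clearly below that of compound 3. Whether an amine or a hydroxyl group in this place would give a true number, and whether methylsulfanyl on another carbon of the ring would read the same, also stays unanswered.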